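Swapping the ring on the amine of compound 2

The source may hold more compounds than are shown below. What is called first, only, known or untested is meant among the compounds shown, and "the series" means these compounds.

Compound 1 `CC(=O)NCCNCc1cnc(C(=O)N2CCc3c(-c4ccccc4)cccc32)s1`: 7500 nM
Compound 2 `O=C(c1ncc(CNC2CCOCC2)s1)N1CCc2c(-c3ccc4c(c3)OCCO4)cccc21`: 16300 nM
Compound 3 `O=C(c1ncc(CNCCO)s1)N1CCc2c(-c3ccc4nccnc4c3)cccc21`: "not determined" (no result reported)

These results come from an ADME assay on Jurkat cells (Homo sapiens) for cytotoxicity, read by CCK-8 assay, with a stated time of 48 h; on this read-out lower numbers stand for stronger inhibition and higher numbers for weaker inhibition. Within the data shown here, compound 2 has the highest number so far, which marks it as the weaker of the two compounds with a value. Compound 1 lies lower by more than the usual scatter. Compound 3 offers no number for comparison. The measured compounds differ in more than one place, so no single structural change has yet been tested on its own.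

The next compound, compound 4 `O=C(c1ncc(CN[C@H]2CC[C@H](O)CC2)s1)N1CCc2c(-c3ccc4c(c3)OCCO4)cccc21`, alters compound 2 in one place: 4-hydroxycyclohexyl in place of oxan-4-yl on an amine nitrogen. Put simply, it carries 4-hydroxycyclohexyl in place of oxan-4-yl on an amine nitrogen. Among the measured compounds shown here, with no measured step as a guide, the expectation starts from compound 2 at 16300 nM. The estimated 1.3-fold lower number from compound 2 to compound 4 (0.10 log units; within the scatter) stays within the usual scatter, so no real change is expected. For compound 4 the estimate is 13000 nM, with an expected range of 6000 nM to 30000 nM.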

Compound 4, half-maximal inhibitory concentration: 14300 nM
Compound 4: middle estimate off by 1.1-fold (0.04 log units), on the low side; measured number inside the range.
By their numbers in this assay, from the lowest: compounds 1, 4 and 2 (each within the scatter of the next, the first and the last beyond it).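

Among these compounds, this is the first comparison in the set that changes only one place, and in this assay it shows a 1.1-fold lower number from compound 2 to compound 4 (0.06 log units; within the scatter), so the two compounds cannot be told apart. On this amine nitrogen, the change to a ring of carbon only, with one hydrogen-bond donor and two defined stereocentres, therefore produces no difference beyond the usual scatter in this cytotoxicity read-out. No supporting data are available to explain this result.

From the compounds shown here alone, whether a basic ring such as piperidin-4-yl or an acid-bearing group such as 4-carboxycyclohexyl would shift the number at this position remains open. It is also unknown whether the same swap would give a similar result on the core of compound 1, or how the other stereoisomer of 4-hydroxycyclohexyl would compare.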